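From 3-(dimethylamino)propyl to 4-aminocyclohexyl on a shared core

The source may hold more compounds than are shown below. What is called first, only, known or untested is meant among the compounds shown, and "the series" means these compounds.

Compound 1 `C[C@@H](Nc1c(C(=O)NCc2ccc(F)cc2)nc(Br)c2cccnc12)c1ccccc1` gives "not determined" (no result reported)
Compound 2 `CN(C)CCCNc1c(C(=O)NCc2ccc(F)cc2)nc(Br)c2cccnc12` gives 7000 nM

For the measured compounds named here, in a functional assay on MCF7 cells (Homo sapiens) for cytotoxicity, read by MTT assay, with a stated time of 72 h (a lower number here means a stronger inhibitor, a higher number a weaker inhibitor), compound 2 is the only compound with a number (7000 nM), so it cannot be ranked against anything. Compound 1 has no result to compare ("not determined" (no result reported)). Compound 3 `N[C@H]1CC[C@H](Nc2c(C(=O)NCc3ccc(F)cc3)nc(Br)c3cccnc23)CC1` has not yet been measured. It carries 4-aminocyclohexyl in place of 3-(dimethylamino)propyl on a nitrogen on an aromatic ring and otherwise keeps the shared core. Going by the values given here, no measured pair shows what such a change does, so the expectation in this assay is for no change beyond the scatter, with no firm direction. That expectation rests on compound 2 alone (7000 nM). The expected size of the change is small, an estimated 1.4-fold lower number from compound 2 to compound 3 (0.15 log units; within the scatter) in this measurement. Compound 3 is estimated at 5000 nM with an expected range from 1500 nM to 17000 nM in this measurement.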

Compound 3, half-maximal inhibitory concentration: 2000 nM
Compound 3: the middle estimate sits 2.5-fold (0.40 log units) above what was measured; the range from low to high includes it.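

In this assay, 4-aminocyclohexyl in place of 3-(dimethylamino)propyl on a nitrogen on an aromatic ring gives a 3.5-fold lower number from compound 2 to compound 3 (0.54 log units; beyond the scatter) and this modest step lies beyond the scatter. For the compounds shown here, it is the first readable step at this position, and it shows that the number responds to the group on this nitrogen, with the ring-bearing group giving the lower number. No measured evidence bears on what lies behind this step.

The change brings in a six-membered ring, a hydrogen-bond donor and two defined stereocentres at once, so the compounds shown do not separate their contributions. A plain cyclohexyl without the amine, a dimethylamino group on the same ring, or the other stereoisomer of 4-aminocyclohexyl would each bear on that question.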